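Compound 2 and Its (4-Methoxyphenyl)carbonyl Ester in Cytotoxicity

A few compounds are considered here, and "the series" means these few. Any claim that something is new, unique, unknown or untested is made for them only; others in the source may bear on it.

Compound 1 `C=C1CC[C@@H]2[C@](C)(CO)[C@H](O)CC[C@@]2(C)[C@@H]1CCC1=CCOC1=O` — "not active" (no number reported)
Compound 2 `C=C1CC[C@@H]2[C@](C)(CO)[C@H](O)CC[C@@]2(C)[C@@H]1CCc1ccoc1` — 79500 nM
Compound 3 `C=C1CC[C@@H]2[C@](C)(COC(=O)CC)[C@H](OC(=O)CC)CC[C@@]2(C)[C@@H]1CCc1ccoc1` — > 100000 nM

Of the compounds shown here, three sharing one core have been tested in a functional assay on MCF7 cells (Homo sapiens) for cytotoxicity, read by MTT assay, with a stated time of 48 h (a higher number here means a weaker inhibitor, a lower number a stronger inhibitor), and compound 2 gives 79500 nM. For the measured compounds named here, that is the only plain number among the three. Compound 1 is reported only as "not active" (no number reported), with no number attached. For compound 3 the result is a limit of the assay, > 100000 nM. Thus one of the three entries is a limit and not a number, as noted in the limit of > 100000 nM in this assay, at which 1 of the 3 values shown sits. Going by the values given here, no step between two measured compounds is available, so compound 2 stands alone as the single numeric point of reference.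

Compound 4 `C=C1CC[C@@H]2[C@](C)(COC(=O)c3ccc(OC)cc3)[C@H](O)CC[C@@]2(C)[C@@H]1CCc1ccoc1` differs from compound 2 in one place: (4-methoxyphenyl)carbonyl in place of hydrogen on an oxygen on a saturated carbon. From the three results shown, the step from compound 2 to compound 4 in this assay is expected to be a 1.4-fold higher number from compound 2 to compound 4 (0.14 log units; within the scatter), that is, toward a weaker inhibitor rather than a stronger one. Compound 4 is therefore estimated at 110000 nM, within a range from 40000 nM to 300000 nM, with a real chance that only a limit is reported.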

Compound 4, half-maximal inhibitory concentration: 25200 nM
Compound 4: middle estimate off by 4.4-fold (0.64 log units), on the high side; measured number below the stated range.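

In this assay the series now has its first readable step, a 3.2-fold lower number from compound 2 to compound 4 (0.50 log units; beyond the scatter), made by placing (4-methoxyphenyl)carbonyl in place of hydrogen on an oxygen on a saturated carbon. The hydrogen of this hydroxy group is therefore not needed for the activity seen, and this position accepts a much larger ester bearing an aromatic ring while the number moves toward a stronger inhibitor, though the step remains a modest one. Compound 3 remains a limit of the assay and not a number, so the series still has only two plain numbers to set side by side: the limit of > 100000 nM in this assay, at which 1 of the 4 values shown sits.

What the compounds shown leave open is which part of the new group matters, as one step cannot separate the carbonyl, the aromatic ring and the methoxy group, and an acetyl ester, an unsubstituted benzoyl ester or an ester carrying an amine at the same oxygen would each speak to this. Going by these compounds, whether (4-methoxyphenyl)carbonyl would act alike on the other hydroxy group, or on the core of compound 1, also stays open.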